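The source may hold more compounds than are shown below. What is called first, only, known or untested is meant among the compounds shown, and "the series" means these compounds.

In an ADME assay on HepG2 cells (Homo sapiens) for cytotoxicity, read by luminescence, CellTiter-Glo and ATP content, with a stated time of 72 h (on this read-out lower numbers stand for an effect already at smaller amounts and higher numbers for an effect only at larger amounts of compound), the measured compounds stand as follows:
- compound 1, `Fc1ccc(-c2ccc3c(NCCCNCc4ccco4)ccnc3c2)cc1`, gives 7760 nM
- compound 2, `Cc1cc(C)cc(Cc2ccc3c(NCCCNCc4ccco4)ccnc3c2)c1`, gives 6270 nM
- compound 3, `COc1ccc(F)cc1CNCCCNc1ccnc2cc(-c3cccc4ccccc34)ccc12`, gives 16000 nM

Compound 3 carries the highest of the three numbers; compound 1 lies nearest to it and compound 2 furthest, both gaps beyond the scatter. Among the measured compounds shown here, the only step between compounds that differ in one place is a 1.2-fold lower number from compound 1 to compound 2 (0.09 log units; within the scatter), and it concerns the aromatic carbon of the core, not the amine side.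

Compound 4, `c1coc(CNCCCNc2ccnc3cc(-c4cccc5ccccc45)ccc23)c1`, keeps the core of compound 3 and differs from it only as furan-2-yl in place of 5-fluoro-2-methoxyphenyl on a saturated chain carbon bound to an amine nitrogen. For the measured compounds named here, no measured step bears directly on this change. What can be said is that compounds 1 and 2, which already carry the (furan-2-yl)methyl amine, both sit lower than compound 3. On that basis a modest move toward the lower numbers is expected in this assay, estimated as a 1.6-fold lower number from compound 3 to compound 4 (0.20 log units; within the scatter), though it may not exceed the scatter. Compound 4 is therefore expected to give about 10000 nM, within 4000 nM to 25000 nM.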

Compound 4, half-maximal effective concentration: 5600 nM
The estimate for compound 4 lay 1.8-fold (0.25 log units) above the measured number; low and high end bracket the measured number.
By their numbers in this assay, from the lowest: compounds 4, 2 and 1 (each within the scatter of the next); then compound 3.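

In this assay, furan-2-yl in place of 5-fluoro-2-methoxyphenyl on a saturated chain carbon bound to an amine nitrogen gives a 2.9-fold lower number from compound 3 to compound 4 (0.46 log units; beyond the scatter) and is the only single change shown at the amine side, as well as the only one that goes beyond the scatter. With the (furan-2-yl)methyl amine kept, naphthalen-1-yl on the aromatic carbon gives a 1.1-fold lower number from compound 2 to compound 4 (0.05 log units; within the scatter) and a 1.4-fold lower number from compound 1 to compound 4 (0.14 log units; within the scatter) and so cannot be told apart from the other two groups there. Nothing at hand explains the step at the amine side.

Going by these compounds, whether the step holds with 4-fluorophenyl or 3,5-dimethylbenzyl on the aromatic carbon stays open, as 5-fluoro-2-methoxybenzyl appears only with naphthalen-1-yl. On these data alone, it is also open what a plain benzyl, a cyclohexylmethyl or a longer chain on that amine nitrogen would give in this assay with the same core.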